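Swapping fluoro for methoxy on a benzyloxy chalcone

A few compounds are considered here, and "the series" means these few. Any claim that something is new, unique, unknown or untested is made for them only; others in the source may bear on it.

This small set of compounds shares a chalcone-like core in which two aromatic rings are joined through a carbonyl and a double bond. Compound 1 `O=C(/C=C/c1ccccc1Cl)c1ccc(OCc2ccccc2)cc1` carries a chloro group on one ring and a benzyloxy group on the other; in a functional assay on HCT-116 cells (Homo sapiens) for antiproliferative activity, read by sulforhodamine B assay, with a stated time of 3 days, tested at 25 uM (a lower number here means a weaker effect, a higher number a stronger effect of the compound at the concentration tested), compound 1 gives 54.5%. Compound 3 `O=C(/C=C/c1ccc(F)cc1)c1ccccc1` has a fluoro group and no benzyloxy group, and in this assay compound 3 gives 86.8%. Compound 2 `O=C(/C=C/c1ccc(F)cc1)c1ccc(OCc2ccccc2)cc1` combines the fluoro group of compound 3 with the benzyloxy group of compound 1, but in this assay compound 2 gives "not determined" (no result reported), so no number is available for it and it cannot be placed among the other two.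

Compound 4 `COc1ccc(/C=C/C(=O)c2ccc(OCc3ccccc3)cc2)cc1` differs from compound 2 in one place: methoxy in place of fluoro on an aromatic carbon. Going by the values given here, no measured pair shows the effect of such a change, so the size and direction of the step in this assay cannot be drawn from the data; a step no larger than the usual scatter is as plausible as a modest shift either way. Given that compound 1, the other benzyloxy compound, gives 54.5%, compound 4 is expected to give about 50%, with a likely range from 20% to 80%.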

Compound 4, a percentage reported as inhibition, at one concentration (the size of the read-out at that concentration, not a potency): 9.5%
Compound 4: the middle estimate sits 40.5 percentage points above what was measured; measured number outside the range, below it.
By their numbers in this assay, from the lowest: compound 4; then compound 1; then compound 3.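

In this assay, going by these compounds alone, the one readable step is a large drop a number 45 percentage points lower from compound 1 to compound 4 (beyond the scatter) with 4-methoxyphenyl in place of 2-chlorophenyl and the benzyloxy side unchanged. This shows that, with benzyloxy held fixed, the choice of aromatic group on the double-bonded chain carbon can change the read-out at the tested concentration by far more than the usual scatter, which compound 1 alone could not reveal. The step changes both the group on the ring and where it sits, so this pair cannot separate the two, and no measurement shown explains the drop.

Going by these compounds, compound 2 has no reported number, so the step from fluoro to methoxy on the 4-substituted phenyl ring cannot be read, and the effect of that swap remains unknown. Also open, on these data alone, is whether the low read-out of compound 4 is particular to methoxy, or whether an amine or a longer chain such as butoxy in the same place, on the same benzyloxy-bearing core, would give a similar number.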